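Swapping the nitrile for a phenyl at the amide end

The compounds below may be only part of what the source reports. "The series", "measured", "known", "first", "only" and "open" are said of these compounds alone.

Compound 1 `O=C(Nc1cccc(-c2oc3cc(-c4ccc(F)cc4)ccc3c(=O)c2O)c1)c1ccc(C(F)(F)F)cc1`: 42700 nM
Compound 2 `Cc1cc(C)cc(C(=O)Nc2cccc(-c3oc4cc(-c5ccc(F)cc5)ccc4c(=O)c3O)c2)c1`: 13400 nM
Compound 3 `N#Cc1ccc(C(=O)Nc2cccc(-c3oc4cc(-c5ccc(F)cc5)ccc4c(=O)c3O)c2)cc1`: 7110 nM

All three compounds share the same core and differ only in the group attached to the amide carbonyl. Among the measured compounds shown here, in a functional assay on HepG2 cells (Homo sapiens) for antiproliferative activity, read by CCK-8 assay, with a stated time of 72 h (on this read-out higher numbers stand for weaker inhibition and lower numbers for stronger inhibition), compound 3 gives the lowest of the three numbers, although its distance to compound 2 lies within the scatter, so the two cannot be ranked; only the step of a 6.0-fold lower number from compound 1 to compound 3 (0.78 log units; beyond the scatter) is clearly beyond it, and the step of a 1.9-fold lower number from compound 2 to compound 3 (0.28 log units; within the scatter) is not.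

Compound 4 `O=C(Nc1cccc(-c2oc3cc(-c4ccc(F)cc4)ccc3c(=O)c2O)c1)c1ccc(-c2ccccc2)cc1` carries the change (phenyl in place of cyano on an aromatic carbon). For the measured compounds named here, two measured steps bear on it. Exchanging the trifluoromethyl for the nitrile, a 6.0-fold lower number from compound 1 to compound 3 (0.78 log units; beyond the scatter), was a modest move downward. Exchanging the 3,5-dimethylphenyl for the 4-cyanophenyl, a 1.9-fold lower number from compound 2 to compound 3 (0.28 log units; within the scatter), stayed within the scatter. Going by the values given here, neither step tests a group as large as phenyl, and a group without a hydrogen-bond acceptor in this place has been seen only in compounds 1 and 2, both with higher numbers than compound 3. On that basis a step upward of modest size, a 2.1-fold higher number from compound 3 to compound 4 (0.32 log units; beyond the scatter), is expected, with wide uncertainty. Compound 4 is therefore estimated at 15000 nM, within a range from 4000 nM to 60000 nM.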

Compound 4, half-maximal inhibitory concentration: 88500 nM
The estimate for compound 4 lay 5.9-fold (0.77 log units) below the measured number; measured number above the stated range.
By their numbers in this assay, from the lowest: compounds 3 and 2 (each within the scatter of the next); then compound 1; then compound 4.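

In this assay, among the compounds shown here, the position on the aromatic carbon para to a large group proves far less forgiving than the earlier compounds suggested: replacing cyano with phenyl gives the largest step seen so far (a 12-fold higher number from compound 3 to compound 4 (1.10 log units; beyond the scatter)). The 4-phenylphenyl group also compares poorly with the 3,5-dimethylphenyl group (a 6.6-fold higher number from compound 2 to compound 4 (0.82 log units; beyond the scatter)) and, by a smaller margin, with trifluoromethyl at the same position (a 2.1-fold higher number from compound 1 to compound 4 (0.32 log units; beyond the scatter)), so compound 4 is the weakest of the four, with all its steps beyond the scatter. The shown data offer no measurement that explains why this added aromatic ring raises the number so sharply.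

As far as these compounds go, what remains open is whether any second ring at this position gives such a high number, or whether this result belongs to phenyl alone. A pyridine ring, a morpholine ring or a carboxylic acid in the same place, each compared directly with compound 3 and compound 4, would help separate the effect of adding a ring from that of losing the nitrile.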